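The source may hold more compounds than are shown below. What is called first, only, known or untested is meant among the compounds shown, and "the series" means these compounds.

Among the measured compounds shown here, compound 1 `CN(C)c1ccc(/C=C2\CCC/C(=C\c3ccccc3[N+](=O)[O-])C2=O)cc1` gives 122000 nM in a functional assay on MOLT-4 cells (Homo sapiens) for cytotoxicity, with a stated time of 72 h (on this read-out higher numbers stand for weaker inhibition and lower numbers for stronger inhibition), the highest of the three numbers measured so far: compound 3 `CN(C)c1ccc(/C=C2\CCC/C(=C\c3cccc([N+](=O)[O-])c3)C2=O)cc1` gives 10900 nM and compound 2 `O=C1/C(=C/c2ccc(Cl)cc2)CCC/C1=C\c1ccc([N+](=O)[O-])cc1` gives 9120 nM. Compound 4 `O=C1/C(=C/c2ccc(F)cc2)CCC/C1=C\c1ccccc1[N+](=O)[O-]` has not yet been measured; it differs from compound 1 by fluoro in place of dimethylamino on an aromatic carbon. For the measured compounds named here, the only measured step, an 11-fold lower number from compound 1 to compound 3 (1.05 log units; beyond the scatter), concerns the nitrophenyl group rather than the dimethylamino position, so no measured step bears directly on this change. Compound 2, which carries chloro rather than dimethylamino together with a differently placed nitro group, shows a lower number than compound 1, but two places differ there. Compound 4 is therefore expected to show a 3.1-fold lower number from compound 1 to compound 4 (0.48 log units; beyond the scatter), with wide uncertainty. The estimate for compound 4 is 40000 nM, between 8000 nM and 150000 nM.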

Compound 4, half-maximal inhibitory concentration: 1870 nM
Compound 4: middle estimate off by 21-fold (1.33 log units), on the high side; measured number below the stated range.
By their numbers in this assay, from the lowest: compound 4; then compounds 2 and 3 (each within the scatter of the next); then compound 1.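

Among the compounds shown here, the step of a 65-fold lower number from compound 1 to compound 4 (1.81 log units; beyond the scatter) in this assay is the first measured change at this aromatic carbon, and it shows that replacing dimethylamino with fluoro moves the number strongly while the 2-nitrophenyl group stays fixed. This position is thus as capable of a large step as the nitro placement, seen in an 11-fold lower number from compound 1 to compound 3 (1.05 log units; beyond the scatter). Nothing measured here accounts for the step.

Going by these compounds, whether the step comes from losing dimethylamino or from gaining fluoro remains open; an unsubstituted phenyl, a methoxy group or a primary amine at this position would separate the two. On these data alone, whether fluoro gives a similar step alongside a 3-nitrophenyl group also remains open.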